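Adding cyclohexyl to the amino group of compound 3

This account rests on a few compounds, and the source may have more. Where it says the series, first, only, none or still open, it means among the compounds named here.

Measured so far in a functional assay on A549 cells (Homo sapiens) for antiproliferative activity, read by MTT assay (on this read-out higher numbers stand for weaker inhibition and lower numbers for stronger inhibition), of three related compounds
Compound 1 `CCCOC(=O)N1CCCc2cc(S(=O)(=O)N3CC(c4ccccc4)NC3=O)ccc21` gives 1030 nM
Compound 2 `O=C(CCl)N1CCCc2cc(S(=O)(=O)N3CC(c4ccccc4)NC3=O)ccc21` has the entry "not determined" (no result reported)
Compound 3 `NC(=O)N1CCCc2cc(S(=O)(=O)N3CC(c4ccccc4)NC3=O)ccc21` gives 2540 nM

Compound 3 at 2540 nM holds the higher of the two available numbers, so it is the weaker inhibitor of the pair. Compound 4 `O=C(NC1CCCCC1)N1CCCc2cc(S(=O)(=O)N3CC(c4ccccc4)NC3=O)ccc21` differs from it in one place: cyclohexyl in place of hydrogen on an amide-type nitrogen with cyclohexyl in place of hydrogen on an amide-type nitrogen. For the measured compounds named here, only the step of a 2.5-fold higher number from compound 1 to compound 3 (0.39 log units; beyond the scatter) bears on this, with amino in place of propoxy on a carbonyl carbon. Compound 4 keeps carbon groups on that amino nitrogen, so a modest move to a lower number is expected, though one step is thin evidence. The expected change is a 2.3-fold lower number from compound 3 to compound 4 (0.36 log units; beyond the scatter) in this assay by this reading. For compound 4 the estimated value is 1100 nM with an expected range of 300 nM to 3500 nM in this estimate.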

Compound 4, half-maximal inhibitory concentration: 231 nM
Compound 4: middle estimate off by 4.8-fold (0.68 log units), on the high side; measured number outside the range, below it.
By their numbers in this assay, from the lowest: compound 4; then compound 1; then compound 3.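

In this assay, the amide-type nitrogen proves to be a place where one added group changes a great deal: cyclohexyl in place of hydrogen gives an 11-fold lower number from compound 3 to compound 4 (1.04 log units; beyond the scatter). Cyclohexylamino in place of propoxy on the carbonyl carbon also gives a 4.5-fold lower number from compound 1 to compound 4 (0.65 log units; beyond the scatter), so the loss seen with plain amino does not hold once cyclohexyl is attached. Nothing measured here explains this gain. Still open, as far as these compounds go, is whether an open chain such as hexyl, or a phenyl ring, on this nitrogen would match cyclohexyl.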